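This account rests on a few compounds, and the source may have more. Where it says the series, first, only, none or still open, it means among the compounds named here.

Measured so far in a functional assay on HGC-27 cells (Homo sapiens) for inhibition, read by MTT assay, with a stated time of 72 h; on this read-out lower numbers stand for stronger inhibition and higher numbers for weaker inhibition:

- compound 1, `C[C@@H]1CCN(c2cc(-c3ccccc3)nc3ncnn23)C[C@@H]1N(C)c1ncnc2[nH]ccc12`, gives > 100000 nM, a limit of the assay.
- compound 2, `CCc1cc(N2CC[C@@H](C)[C@@H](N(C)c3ncnc4[nH]ccc34)C2)n2ncnc2n1`, gives > 100000 nM, likewise a limit.
- compound 3, `C=CCSc1nc2nc(C)cc(N3CC[C@@H](C)[C@@H](N(C)c4ncnc5[nH]ccc45)C3)n2n1`, gives 35200 nM.

Going by the values given here, compound 3 carries the only number in this assay; the other two values are limits, as the limit of > 100000 nM in this assay, at which 2 of the 3 values shown sit, states. The step that the two limits leave unreadable from compound 1 to compound 2 therefore cannot be read in size. Compound 4, `Cc1cc(N2CC[C@@H](C)[C@@H](N(C)c3ncnc4[nH]ccc34)C2)n2nc(SCc3ccc([N+](=O)[O-])cc3)nc2n1`, differs from compound 3 by 4-nitrophenyl in place of vinyl on a saturated chain carbon bound to a sulfur, that is allylsulfanyl to (4-nitrobenzyl)sulfanyl. Among the compounds with values here, no measured step touches this position, so no direction is supported and a step within scatter is expected, a 1.2-fold lower number from compound 3 to compound 4 (0.07 log units; within the scatter). Compound 4 is estimated at 30000 nM, between 8000 nM and 100000 nM.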

Compound 4, half-maximal inhibitory concentration: 29400 nM
Compound 4: the middle estimate sits 1.0-fold (0.01 log units) above what was measured, and the stated range covers the measured number.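

Going by these compounds alone, this position is the first with a readable step: in this assay, the change from allylsulfanyl to (4-nitrobenzyl)sulfanyl gives a 1.2-fold lower number from compound 3 to compound 4 (0.08 log units; within the scatter). A six-membered aromatic ring of carbon only can therefore enter on the saturated chain carbon bound to a sulfur without a step beyond the scatter. Both values here are numbers, while the rest of the series gives only limits: the limit of > 100000 nM in this assay, at which 2 of the 4 values shown sit.

As far as these compounds go, whether an amine or a carboxylic acid on this chain would shift the number stays open. The step between the two limit compounds cannot be read.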